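Working notes: neopentyloxy to ethylsulfanyl on the carbonyl

A few compounds are considered here, and "the series" means these few. Any claim that something is new, unique, unknown or untested is made for them only; others in the source may bear on it.

Measured so far:
compound 1 `CC(C)OC(=O)N1CCC(Oc2ncnc3c2CCN3c2ccc(S(C)(=O)=O)cc2F)CC1` — 91%
compound 2 `CC(C)COC(=O)N1CCC(Oc2ncnc3c2CCN3c2ccc(S(C)(=O)=O)cc2F)CC1` — 94%
compound 3 `CC(C)(C)COC(=O)N1CCC(Oc2ncnc3c2CCN3c2ccc(S(C)(=O)=O)cc2F)CC1` — 80%

In a functional assay on CHO-K1 cells with Glucose-dependent insulinotropic receptor (Homo sapiens) as the target, read by a luciferase reporter, with a stated time of 5 h (a lower number here means a smaller maximal response, a higher number a larger maximal response), compound 3 holds the lowest of the three numbers. The step of a number 11 percentage points lower from compound 1 to compound 3 (beyond the scatter) and the step of a number 14 percentage points lower from compound 2 to compound 3 (beyond the scatter) both fall beyond the scatter, each modest in size, while the step of a number 3 percentage points higher from compound 1 to compound 2 (within the scatter) stays within it; so the two compounds with the isopropyl or the isobutyl group sit together, and compound 3 with the neopentyl group sits apart and lower.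

Compound 4 `CCSC(=O)N1CCC(Oc2ncnc3c2CCN3c2ccc(S(C)(=O)=O)cc2F)CC1` differs from compound 3 as follows: ethylsulfanyl in place of neopentyloxy on a carbonyl carbon. For the measured compounds named here, the steps that bear on this are the two that vary the group on the carbonyl carbon, a number 11 percentage points lower from compound 1 to compound 3 (beyond the scatter) and a number 14 percentage points lower from compound 2 to compound 3 (beyond the scatter). Going by the values given here, no measured step exchanges oxygen for sulfur at this place, so that part of the change is unsupported by the series. Given that every other group tried at this place gave a higher number than compound 3, the expectation is a moderate rise rather than a further fall, with wide uncertainty.

For compound 4 the maximal response in this assay is estimated at 88%, within 74% to 100%. This estimate corresponds to an expected step of a number 8 percentage points higher from compound 3 to compound 4 (within the scatter).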

Compound 4, largest response reached (reported as percent of maximum), in percent of the reference or control that the assay uses: 128%
The estimate for compound 4 lay 40 percentage points below the measured number; the measured number lies above the stated range.
By their numbers in this assay, from the lowest: compound 3; then compounds 1 and 2 (each within the scatter of the next); then compound 4.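

Up to compound 3, changes to the group on the carbonyl carbon had left the number level or lowered it; ethylsulfanyl shows that this place can also raise the maximal response well past that level in this assay (a number 48 percentage points higher from compound 3 to compound 4 (beyond the scatter)). The rise holds against each of the other groups, not only neopentyloxy (a number 34 percentage points higher from compound 2 to compound 4 (beyond the scatter); a number 37 percentage points higher from compound 1 to compound 4 (beyond the scatter)), and compound 4 stands highest of the four. This single change both exchanges oxygen for sulfur and replaces a branched chain with a shorter, unbranched one, so the compounds shown cannot assign the rise to either part.

Ethoxy on the same carbonyl carbon, or isopropylsulfanyl and longer chains on sulfur, would separate the two parts. Nothing available explains the size of this rise.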